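From chloro to fluoro on compound 1

The source may hold more compounds than are shown below. What is called first, only, known or untested is meant among the compounds shown, and "the series" means these compounds.

- compound 1 `O=C(Nc1ccc(C(F)(F)F)cc1)c1ccc(Cl)cc1O`: 670 nM
- compound 2 `N#Cc1ccc(NC(=O)c2ccc3cccnc3c2O)cc1`: 180 nM
- compound 3 `N#Cc1ccc(NC(=O)c2ccc3cccnc3c2O)c(C#N)c1`: 270 nM

In a functional assay on Jurkat cells (Homo sapiens) for cytotoxicity, read by luminescence and CellTiter-Glo, with a stated time of 3 days (a higher number here means a weaker inhibitor, a lower number a stronger inhibitor), compound 1 gives 670 nM, the highest of the three numbers and beyond the scatter from both others. Compound 4 `O=C(Nc1ccc(C(F)(F)F)cc1)c1ccc(F)cc1O`, not yet measured, carries fluoro in place of chloro on an aromatic carbon. Among the measured compounds shown here, the only measured step, a 1.5-fold higher number from compound 2 to compound 3 (0.18 log units; within the scatter), lies within the scatter, but it adds cyano on a different core, so it offers only weak guidance. For the measured compounds named here, no measured pair makes this swap. In this assay no step beyond the scatter is therefore expected, in either direction. The estimated step is a 1.3-fold higher number from compound 1 to compound 4 (0.13 log units; within the scatter). For compound 4 the estimate is 900 nM, with an expected range from 350 nM to 2300 nM.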

Compound 4, half-maximal inhibitory concentration: 800 nM
Estimate against measurement, compound 4: 1.1-fold (0.05 log units) above; measured number inside the range.
By their numbers in this assay, from the lowest: compounds 2 and 3 (each within the scatter of the next); then compounds 1 and 4 (each within the scatter of the next).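

In this assay, among the compounds shown here, the first pair changing only this position gives a step (a 1.2-fold higher number from compound 1 to compound 4 (0.08 log units; within the scatter)) that stays within the scatter. So on the core of compound 1, para to a large group and meta to a hydroxy group, chloro can give way to fluoro without a clear change in the number. No measurement here explains this result.

Going by these compounds, whether this position tolerates only halogens remains open, since an amine, a methoxy group or a carboxylic acid could behave differently. The same swap on the core of compound 2 is also untested among the compounds shown.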